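This account rests on a few compounds, and the source may have more. Where it says the series, first, only, none or still open, it means among the compounds named here.

Measured compounds:
compound 1 `COc1cc(-c2cc(C(=O)/C=C/c3ccc(Cl)cc3)nc3cc(-c4ccccc4)nn23)cc(OC)c1OC`: 21600 nM
compound 2 `COc1cc(-c2cc(/C=C/C(=O)c3ccc(C)cc3)nc3cc(-c4ccccc4)nn23)cc(OC)c1OC`: 23900 nM
compound 3 `COc1cc(-c2cc(/C=C/C(=O)c3ccc(C)c(C)c3)nc3cc(-c4ccccc4)nn23)cc(OC)c1OC`: 13500 nM

In a functional assay on MDA-MB-231 cells (Homo sapiens) for antiproliferative activity, read by MTT assay, with a stated time of 24 h (on this read-out higher numbers stand for weaker inhibition and lower numbers for stronger inhibition), compound 1 gives 21600 nM, the second highest of the three numbers; compound 2 sits nearest, and compound 3 sits furthest, both within the usual scatter of it. The unmeasured compound 4 `COc1cc(/C=C/C(=O)c2cc(-c3cc(OC)c(OC)c(OC)c3)n3nc(-c4ccccc4)cc3n2)cc(OC)c1OC` differs from compound 1 in one place: 3,4,5-trimethoxyphenyl in place of 4-chlorophenyl on a double-bonded chain carbon bound to a double-bonded chain carbon.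

The measured steps offer only indirect guidance. The step from compound 1 to compound 2 (a 1.1-fold higher number from compound 1 to compound 2 (0.04 log units; within the scatter)) and the step from compound 1 to compound 3 (a 1.6-fold lower number from compound 1 to compound 3 (0.20 log units; within the scatter)) each exchange the whole arm that carries the aryl group, and the step from compound 2 to compound 3 (a 1.8-fold lower number from compound 2 to compound 3 (0.25 log units; within the scatter)) adds a single methyl; every one of them lies within the scatter. Among the measured compounds shown here, no measured pair places a trimethoxyphenyl where the 4-chlorophenyl of compound 1 stood, so the change to compound 4 is not directly covered. Given that the three aryl variations seen so far all stayed within the scatter, compound 4 is expected to give a number close to that of compound 1, with no step beyond the scatter: a 1.1-fold lower number from compound 1 to compound 4 (0.03 log units; within the scatter). The estimate for compound 4 is therefore 20000 nM, with a range from 8000 nM to 50000 nM.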

Compound 4, half-maximal inhibitory concentration: 18400 nM
Compound 4: the middle estimate sits 1.1-fold (0.04 log units) above what was measured; low and high end bracket the measured number.
By their numbers in this assay, from the lowest: compounds 3, 4, 1 and 2 (each within the scatter of the next).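

In this assay, putting 3,4,5-trimethoxyphenyl in place of 4-chlorophenyl on a double-bonded chain carbon bound to a double-bonded chain carbon gives a 1.2-fold lower number from compound 1 to compound 4 (0.07 log units; within the scatter), and this is the first step shown that exchanges the aryl group alone, whereas the earlier steps exchanged the whole arm or added a single methyl. The entering group is clearly larger, with 12 heavy atoms against 7, and it brings 3 hydrogen-bond acceptors where the leaving group has 0, yet the step stays within the scatter, so at this place the read-out does not separate these two aryl groups. No supporting data are available that bear on this result.

The compounds shown leave open whether a dimethylamino group or a carboxylic acid on this aryl ring, or a longer chain in its place, would move the number beyond the scatter. They also leave open how 3,4,5-trimethoxyphenyl would behave on the arm that compound 2 carries, where only methyl-substituted phenyl groups appear here.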